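This account rests on a few compounds, and the source may have more. Where it says the series, first, only, none or still open, it means among the compounds named here.

Measured compounds:
compound 1, `CN(C)CCCn1nc(C2=C(c3cn(C)c4ccccc34)C(=O)NC2=O)c2cccnc21` — > 100000 nM in a functional assay on ECa-109 cells (Homo sapiens) for antiproliferative activity, read by MTT assay, with a stated time of 48 h; a higher number here means a weaker inhibitor, a lower number a stronger inhibitor
compound 2, `COc1ccc(N2C(=O)C(c3cn(C)c4ccccc34)=C(c3nn(CCCN4CCCCC4)c4ncccc34)C2=O)cc1` — 3340 nM in this assay
compound 3, `Cn1cc(C2=C(c3nn(CCCn4cccc4)c4ncccc34)C(=O)NC2=O)c2ccccc21` — > 100000 nM in this assay

Compound 3 stands at a limit of this assay, not at a number; its result is > 100000 nM. Compound 1 likewise gives only a limit, > 100000 nM. Two of the three values shown sit at this limit, as noted in the limit of > 100000 nM in this assay, at which 2 of the 3 values shown sit. Within the data shown here, compound 2 is the only member of the set with a numerical reading, 3340 nM.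

The step that the two limits leave unreadable from compound 1 to compound 3 cannot be sized, since both ends sit at the limit. Among the measured compounds shown here, no other step among the measured compounds is readable, and none links compound 2 to the rest by a single change.

Compound 4, `Cn1cc(C2=C(c3nn(CCCN4CCCCC4)c4ncccc34)C(=O)NC2=O)c2ccccc21`, is not yet measured. It differs from compound 3 by piperidin-1-yl in place of 1H-pyrrol-1-yl on a saturated chain carbon, three bonds along the chain from an aromatic nitrogen. For the measured compounds named here, the only measured step touching this place, that from compound 1 to compound 3, is unreadable, so no direction or size can be taken from it; the expectation for compound 4 rests only on compound 3 and compound 1 both sitting at the limit with a free imide. Compound 4 is expected to give 100000 nM in this assay, within 20000 nM to 300000 nM, most likely reported as a limit; the expected step is a number no higher from compound 3 to compound 4 (the limit leaves the size open).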

Compound 4, half-maximal inhibitory concentration: 42300 nM
Compound 4: middle estimate off by 2.4-fold (0.37 log units), on the high side, within the range that was stated.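

In this assay, among these compounds, compound 4 is the only compound keeping the amide hydrogen that has a numerical reading, and the group at the end of the chain accounts for the change: piperidin-1-yl in place of 1H-pyrrol-1-yl gives an at least 2.3-fold lower number from compound 3 to compound 4 (0.37 log units; beyond the scatter), and piperidin-1-yl in place of dimethylamino gives an at least 2.3-fold lower number from compound 1 to compound 4 (0.37 log units; beyond the scatter). As far as these compounds go, this place on the chain therefore responds to the group it carries, which the unreadable step between compound 1 and compound 3 could not show, though both new steps are only bounds and their full size stays unknown: the limit of > 100000 nM in this assay, at which 2 of the 4 values shown sit. With the 3-(piperidin-1-yl)propyl chain held constant, hydrogen in place of 4-methoxyphenyl on the amide-type nitrogen gives a 13-fold higher number from compound 2 to compound 4 (1.10 log units; beyond the scatter), so the group on that nitrogen also moves the number, which compound 2 alone could not show.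

From the compounds shown here alone, it remains open whether a morpholine ring or a longer chain, such as 4-(piperidin-1-yl)butyl, would hold or lower the number at this place. Going by these compounds, it is also open whether a group other than 4-methoxyphenyl on the amide-type nitrogen, such as benzyl, would give a step of similar direction.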